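Swapping the Aryl Group on a Chromone Sigma-1 Ligand

The compounds below may be only part of what the source reports. "The series", "measured", "known", "first", "only" and "open" are said of these compounds alone.

Of the compounds shown here, three sharing one core have been measured in an assay on isolated protein (Cavia porcellus) with Sigma non-opioid intracellular receptor 1 (Homo sapiens) as the target, read by radioligand binding; a lower number here means a stronger inhibitor, a higher number a weaker inhibitor. Compound 1 `CN(C)CCCCCCCCCCOc1ccc2oc(-c3ccccc3)cc(=O)c2c1` gives 297 nM. Within the data shown here, compound 2 `O=c1cc(-c2ccccc2)oc2ccc(OCCCCCCN3CCCC(O)C3)cc12` gives 86 nM, and the one recorded step, a 3.5-fold lower number from compound 1 to compound 2 (0.54 log units; beyond the scatter), concerns the amine end of the chain. Compound 3 `O=c1cc(-c2cccs2)oc2ccc(OCCCCCCN3CCC(O)CC3)cc12` gives 119 nM, the second highest of the three numbers; it sits within the scatter of compound 2 and is separated from compound 1 by a gap beyond the scatter.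

Compound 4 `O=c1cc(-c2ccncc2)oc2ccc(OCCCCCCN3CCC(O)CC3)cc12` has not yet been measured. It differs from compound 3 in one place: pyridin-4-yl in place of thiophen-2-yl on an aromatic carbon. No measured step bears on this aryl position; the only step shown changes the amine, and compound 1 and compound 3 differ in two places at once, so nothing can be isolated from them. Among the measured compounds shown here, the shift from a five-membered to a six-membered heteroaryl therefore carries no precedent here, and the expectation must stay close to compound 3 with a wide range.

He expects compound 4 to give 200 nM in this assay, between 60 nM and 700 nM, a step of a 1.7-fold higher number from compound 3 to compound 4 (0.23 log units; within the scatter) that is estimated to lie within the usual scatter in either direction.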

Compound 4, half-maximal inhibitory concentration: 159 nM
Compound 4: the middle estimate sits 1.3-fold (0.10 log units) above what was measured, within the range that was stated.
By their numbers in this assay, from the lowest: compounds 2, 3, 4 and 1 (each within the scatter of the next, the first and the last beyond it).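

Among these compounds, at this position, on an aromatic carbon next to the ring oxygen, the compounds now give a first reading of the aryl group alone: in this assay the change shows a 1.3-fold higher number from compound 3 to compound 4 (0.13 log units; within the scatter). With the rest of compound 3 held fixed, thiophen-2-yl, a five-membered aromatic ring with 1 hetero atom, and pyridin-4-yl, a six-membered aromatic ring with 1 hetero atom, cannot be told apart in this measurement, so for this one pair the larger ring and the exchange of sulfur for nitrogen leave no effect that stands clear of the scatter. No measured evidence is available that bears on why these two groups read so closely.

Compound 2 differs from compound 3 and from compound 4 in more than one place, so its phenyl group cannot be read against either heteroaryl group, and the hydroxyl position on the amine ring cannot be separated from the aryl change. Also open, as far as these compounds go, is whether pyridin-2-yl, furan-2-yl or a phenyl ring carrying a carboxylic acid on this same carbon would stay within the scatter of compound 3.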